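Cytotoxicity notes on the benzimidazole amide series

The compounds below may be only part of what the source reports. "The series", "measured", "known", "first", "only" and "open" are said of these compounds alone.

Compound 2, `CN(C)c1cc2[nH]c(C3CCCCC3)nc2cc1NC(=O)c1ccccc1`, is the unsubstituted benzamide of the shared core. In an ADME assay on Vero cells (Chlorocebus sabaeus) for cytotoxicity, read by resazurin assay, with a stated time of 3 days (on this read-out lower numbers stand for stronger inhibition and higher numbers for weaker inhibition), compound 2 gives > 100 ug/mL, which is a limit of the assay and not a number. Compound 1, `CCCc1ccc(C(=O)Nc2cc3nc(C4CCCCC4)[nH]c3cc2N(C)C)cc1`, carries a propyl on the aromatic ring of the amide. In this assay compound 1 gives > 100 ug/mL, again a limit and not a number. The step from compound 1 to compound 2, hydrogen in place of propyl on an aromatic carbon, is a step that the two limits leave unreadable from compound 1 to compound 2. Among the compounds with values here, the only evidence on the measured steps is the limit of > 100 ug/mL in this assay, at which 2 of the 2 values shown sit.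

Compound 3, `CN(C)c1cc2[nH]c(C3CCCCC3)nc2cc1NC(=O)c1ccc(OC(F)(F)F)cc1`, differs from compound 2 by trifluoromethoxy in place of hydrogen on an aromatic carbon. Within the data shown here, the one measured step bears on it only loosely, and its size is unreadable, so no direction beyond the scatter is expected. For compound 3 the estimate in this assay is 100 ug/mL, with a range from 40 ug/mL to 200 ug/mL. The expected step from compound 2 to compound 3 is thus a number no higher from compound 2 to compound 3 (the limit leaves the size open), with a fair chance that compound 3 is reported only as a limit.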

Compound 3, half-maximal inhibitory concentration: > 100 ug/mL
Compound 3 gave a limit, no number; the forecaster's own chance of this, stated with the estimate: 65%; the middle value sits exactly at the limit.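

Compound 3 also gives only a limit and not a number in this assay, so no step from compound 1 or compound 2 to compound 3 can be read: the limit of > 100 ug/mL in this assay, at which 3 of the 3 values shown sit.

The compounds shown leave open whether hydrogen, propyl or trifluoromethoxy on the aromatic ring of the amide makes any difference to the read-out in this assay.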